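Compound 4: 2,6-dibromophenyl in place of 2,6-difluorophenyl

The compounds below may be only part of what the source reports. "The series", "measured", "known", "first", "only" and "open" are said of these compounds alone.

Measured so far in an ADME assay on Huh-7 cells (Homo sapiens) for cytotoxicity, read by MTT assay, with a stated time of 4 h, at 37 degrees C; a lower number here means that less compound is tolerated, a higher number that more compound is tolerated:
compound 1 `CCCOCCNc1nc(Oc2ccccc2)nc2[nH]c(=O)c(-c3ccc(F)cc3)cc12`: compound 1 gives 79800 nM
compound 2 `Cn1c(=O)c(-c2c(F)cccc2F)cc2c(N)nc(Nc3ccccc3)nc21`: compound 2 gives 10400 nM
compound 3 `O=C1Nc2nc(Nc3ccccc3)nc(On3nnc4ccccc43)c2CC1c1ccc(Cl)cc1Cl`: compound 3 gives 5500 nM

Compound 2 stands second highest of these three numbers. Its nearest neighbour is compound 3, whose number is lower by an amount within the scatter; the furthest is compound 1, whose higher number lies beyond the scatter. Among the measured compounds shown here, no two measured compounds differ in only one place, so no single-point step is available to lean on. Compound 4 `Cn1c(=O)c(-c2c(Br)cccc2Br)cc2c(N)nc(Nc3ccccc3)nc21` carries one change relative to compound 2: 2,6-dibromophenyl in place of 2,6-difluorophenyl on an aromatic carbon. For compound 4 the expected step of a 1.3-fold lower number from compound 2 to compound 4 (0.11 log units; within the scatter) is small, with a modest move toward a lower number regarded as somewhat likelier than one toward a higher number, and no move beyond the scatter as the most probable outcome. Compound 4 is expected at 8000 nM, within 3000 nM to 25000 nM.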

Compound 4, half-maximal cytotoxic concentration: 800 nM
For compound 4 the middle estimate is 10-fold (1.00 log units) above the measured one; measured number below the stated range.
By their numbers in this assay, from the lowest: compound 4; then compounds 3 and 2 (each within the scatter of the next); then compound 1.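

In this assay, among the compounds shown here, this aromatic carbon proves sensitive: 2,6-dibromophenyl in place of 2,6-difluorophenyl gives a 13-fold lower number from compound 2 to compound 4 (1.11 log units; beyond the scatter) and provides the only single-place step so far. The two groups match in heavy-atom count, hydrogen-bond donors, hydrogen-bond acceptors and net charge, so these counts do not separate them. Nothing available here bears on the reason for a step of this size.

Where 2,6-dichlorophenyl or 2,6-dimethylphenyl would fall at this position remains open. So does whether a single bromine is enough to give a comparable step.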